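The compounds below may be only part of what the source reports. "The series", "measured", "known", "first", "only" and "open" are said of these compounds alone.

Compound 1 `NC(=O)CN(CCC(c1ccccc1)c1ccccc1)C(=O)CN(CCC(c1ccccc1)c1ccccc1)C(=O)CNCC1CCCO1` is one of two compounds with a number in an ADME assay on A549 cells (Homo sapiens) for cytotoxicity, with a stated time of 72 h; on this read-out higher numbers stand for weaker inhibition of growth and lower numbers for stronger inhibition of growth. In this assay compound 1 gives 2570 nM. Compound 2 `NC(=O)CN(CCC(c1ccccc1)c1ccccc1)C(=O)CNCCC(c1ccccc1)c1ccccc1` gives 3080 nM in this assay, and the step of a 1.2-fold higher number from compound 1 to compound 2 (0.08 log units; within the scatter) shows the two values sitting within the scatter of each other, so neither can be called stronger. Compound 3 `NC(=O)CN(CC1CCCO1)C(=O)CNCCC(c1ccccc1)c1ccccc1` has "not determined" (no result reported) in this assay, so no number is available for it.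

Compound 4 `O=C(CN(CCC(c1ccccc1)c1ccccc1)C(=O)CNCC1CCCO1)NCCC(c1ccccc1)c1ccccc1` differs from compound 1 by hydrogen in place of carbamoylmethyl on an amide-type nitrogen. Among the compounds with values here, no measured step involves the same group or the same amide-type nitrogen. Within the data shown here, the only measured step, a 1.2-fold higher number from compound 1 to compound 2 (0.08 log units; within the scatter), removes a larger piece at a different amine and leaves the number inside the scatter, which gives no sign that trimming this scaffold moves the read-out much. The expectation for compound 4 in this assay is therefore a step of a 1.1-fold higher number from compound 1 to compound 4 (0.04 log units; within the scatter) that stays within the scatter. Compound 4 is estimated at 2800 nM, with a likely range from 1200 nM to 6500 nM.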

Compound 4, concentration for 50% growth inhibition: 1060 nM
The estimate for compound 4 lay 2.6-fold (0.42 log units) above the measured number, outside the stated range (below it).
By their numbers in this assay, from the lowest: compound 4; then compounds 1 and 2 (each within the scatter of the next).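

This position on the amide-type nitrogen responds to change: in this assay, replacing carbamoylmethyl with hydrogen gives a modest but real gain in growth inhibition (a 2.4-fold lower number from compound 1 to compound 4 (0.38 log units; beyond the scatter)). The earlier step, at a different nitrogen, stayed within the scatter (a 1.2-fold higher number from compound 1 to compound 2 (0.08 log units; within the scatter)), so the read-out of this series does not simply ignore small edits, and removing a group can strengthen inhibition here even though it removes only four heavy atoms. Nothing measured here gives a reason for this shift.

On these data alone, it remains open whether the gain comes from losing the carbamoylmethyl group itself or from having hydrogen at this nitrogen. A methyl group, a longer chain or a carboxylic acid at the same place would help to separate those two readings.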